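The source may report more compounds than this note shows. Statements on the series, on what has been measured and on what is new or still open speak of the compounds shown alone.

Measured so far in a functional assay on C6 cells (Rattus norvegicus) for cytotoxicity, read by MTT assay, with a stated time of 24 h; a higher number here means a weaker inhibitor, a lower number a stronger inhibitor: compound 1, `CN(C)CCN1CCN(CC(=O)Nc2ccc(-c3nc4ccccc4o3)cc2)CC1`, gives 7010 nM; compound 2, `CN(C)CCN1CCN(CC(=O)Nc2ccc(-c3nc4cc(F)ccc4o3)cc2)CC1`, gives 4390 nM; compound 3, `Cc1cc(-c2nc3ccccc3o2)ccc1NC(=O)CN1CCN(CCCN(C)C)CC1`, gives 38700 nM.

Compound 2 differs from compound 1 by fluoro in place of hydrogen on an aromatic carbon, and the step was a 1.6-fold lower number from compound 1 to compound 2 (0.20 log units; within the scatter). Compound 3 differs from compound 1 in more than one place; the difference between the two cores is not broken down here. Compound 3 has the highest number of the three.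

Compound 4, `Cc1cc(-c2nc3cc(F)ccc3o2)ccc1NC(=O)CN1CCN(CCCN(C)C)CC1`, is not yet measured. It differs from compound 3 by fluoro in place of hydrogen on an aromatic carbon, the same change made from compound 1 to compound 2, at the same place. In this assay the step to compound 4 is expected to be small, about the size of the earlier one, because that step was a 1.6-fold lower number from compound 1 to compound 2 (0.20 log units; within the scatter). The expected step is a 1.6-fold lower number from compound 3 to compound 4 (0.21 log units; within the scatter). Compound 4 is estimated at 24000 nM, between 8000 nM and 80000 nM.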

Compound 4, half-maximal inhibitory concentration: 11800 nM
Compound 4: middle estimate off by 2.0-fold (0.31 log units), on the high side; low and high end bracket the measured number.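

In this assay, going from 1,3-benzoxazol-2-yl to 5-fluoro-1,3-benzoxazol-2-yl gives a 3.3-fold lower number from compound 3 to compound 4 (0.52 log units; beyond the scatter). This step lies beyond the scatter and the earlier one within it, yet the two steps do not differ by more than the scatter of two such steps: the same change on two cores in this assay, a 1.6-fold lower number (0.20 log units; within the scatter) from compound 1 to compound 2 and a 3.3-fold lower number (0.52 log units; beyond the scatter) from compound 3 to compound 4, 2.1-fold (0.31 log units) apart, within the scatter of two such steps. The change therefore carries from the core of compound 1 to the core of compound 3 with no measurable difference in size, but two pairs set no rule for the series and do not explain the size of either step.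

As far as these compounds go, whether chloro or methoxy at the same place would give a step of like size remains open. So does the size of the fluoro step on a core with a longer chain.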